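Oxadiazole ketones with a phenylhexyl chain: adding a pyridyl

The source may report more compounds than this note shows. Statements on the series, on what has been measured and on what is new or still open speak of the compounds shown alone.

Measured compounds:
- compound 1 `COC(=O)c1cccc(-c2nnc(C(=O)CCCCCCc3ccccc3)o2)n1` — 40 nM
- compound 2 `O=C(CCCCCCc1ccccc1)c1ncno1` — 0.7 nM
- compound 3 `O=C(CCCCCCc1ccccc1)c1ncon1` — 10 nM

In an assay on isolated protein for inhibition of liver carboxylesterase 1 (Homo sapiens) (on this read-out higher numbers stand for weaker inhibition and lower numbers for stronger inhibition), compound 3 gives 10 nM, the second highest of the three numbers. Within the data shown here, the only single-point step among the measured compounds is a 14-fold higher number from compound 2 to compound 3 (1.15 log units; beyond the scatter), which changes the attachment of the five-membered ring to the carbonyl and does not concern a substituent on that ring. Among the measured compounds shown here, compound 1 is the only measured compound that carries a group on its five-membered ring, and in this assay compound 1 gives 40 nM; its structure differs from compound 3 in more than one place, so no step to compound 3 is defined and its number is only an indirect reference.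

Compound 4 `O=C(CCCCCCc1ccccc1)c1noc(-c2ccccn2)n1` differs from compound 3 by pyridin-2-yl in place of hydrogen on an aromatic carbon. For the measured compounds named here, no measured step bears directly on this change. On that basis a step of a 1.5-fold higher number from compound 3 to compound 4 (0.18 log units; within the scatter) is expected, that is no shift clearly beyond the scatter, with the higher number of compound 1 kept in view. For compound 4 in this assay the estimate is 15 nM, within the range 3 nM to 60 nM.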

Compound 4, half-maximal inhibitory concentration: 400 nM
Beside the measured number, compound 4's estimate is 27-fold (1.43 log units) below it; measured number outside the range, above it.
By their numbers in this assay, from the lowest: compound 2; then compound 3; then compound 1; then compound 4.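

Pyridin-2-yl in place of hydrogen, on the aromatic carbon next to the ring nitrogen and next to the ring oxygen, gives a 40-fold higher number from compound 3 to compound 4 (1.60 log units; beyond the scatter) in this assay. Among these compounds, this is the first single-place step that adds a group to the five-membered ring, and it shows that inhibition at this carbon is weakened by this group, whereas the earlier step concerned only how the ring is attached to the carbonyl. No available evidence bears on the reason for this loss.

As far as these compounds go, whether the loss is specific to pyridin-2-yl or extends to other groups on this carbon, such as a methyl group, a phenyl ring or pyridin-3-yl, remains open. Also open, from the compounds shown here alone, is whether an amine or a carboxylic acid on the pyridyl ring, or a shorter chain, would change the size of this step.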